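The compounds below may be only part of what the source reports. "The series", "measured", "known", "first", "only" and "open" are said of these compounds alone.

Compound 1 `c1coc(-c2ccccc2OCC2=NCCN2)c1`: in a functional assay for activation of Alpha-1B adrenergic receptor (Homo sapiens), read by calcium flux (a lower number here means that less compound is needed, a higher number that more compound is needed for the effect), compound 1 gives 10 nM.
Compound 2 `c1ccc(-c2cc[nH]n2)c(OCC2=NCCN2)c1`: in this assay compound 2 gives 79.4 nM.

Within the data shown here, of the two measured compounds, compound 2 stands at the higher number; the only recorded step, a 7.9-fold higher number from compound 1 to compound 2 (0.90 log units; beyond the scatter), separates them. Compound 3 `c1ccc(-c2nccs2)c(OCC2=NCCN2)c1` differs from compound 2 in 1,3-thiazol-2-yl in place of 1H-pyrazol-3-yl on an aromatic carbon. Among the measured compounds shown here, no measured step exchanges one five-membered ring with two hetero atoms for another, so the single step that bears on it is that from compound 1 to compound 2. Since that step raised the number modestly and the entering group, like furan-2-yl in compound 1, carries no hydrogen-bond donor, the step from compound 2 to compound 3 is estimated as a 3.2-fold lower number from compound 2 to compound 3 (0.50 log units; beyond the scatter). Compound 3 is therefore expected to give about 25 nM, within 6 nM to 100 nM.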

Compound 3, half-maximal effective concentration: 20 nM
Estimate against measurement, compound 3: 1.3-fold (0.10 log units) above; low and high end bracket the measured number.
By their numbers in this assay, from the lowest: compounds 1 and 3 (each within the scatter of the next); then compound 2.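

The position on the aromatic carbon ortho to a group of 7 heavy atoms distinguishes between five-membered aromatic rings with 2 hetero atoms, since 1,3-thiazol-2-yl for 1H-pyrazol-3-yl gives a 4.0-fold lower number from compound 2 to compound 3 (0.60 log units; beyond the scatter), a change beyond the scatter. The comparison with furan-2-yl gives a 2.0-fold higher number from compound 1 to compound 3 (0.30 log units; within the scatter), which lies within the scatter, so 1,3-thiazol-2-yl and furan-2-yl cannot be told apart here. Among these three rings, only 1H-pyrazol-3-yl, the one with a hydrogen-bond donor, stands apart.

The compounds shown leave open how a phenyl ring, an amine or a carboxylic acid would fare at this place. Nothing available explains the gap between 1H-pyrazol-3-yl and the other two rings.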